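This account rests on a few compounds, and the source may have more. Where it says the series, first, only, none or still open, it means among the compounds named here.

Measured compounds:
compound 1 `O=C1C(NC2CC2)=CC(=O)c2c1nc1n2[C@H]2OC[C@@H](O)[C@H]2OC1` — > 4000 nM
compound 2 `O=C1C=C(Nc2ccccc2)C(=O)c2c1nc1n2[C@H]2OC[C@@H](O)[C@H]2OC1` — 1730 nM

Of the compounds shown here, two on the shared core have been measured. In a functional assay on MGC-803 cells (Homo sapiens) for inhibition, read by sulforhodamine B assay (a higher number here means a weaker inhibitor, a lower number a stronger inhibitor), compound 1 gives > 4000 nM; this is a limit of the assay and not a number. Compound 1 therefore stands at the limit of > 4000 nM in this assay, at which 1 of the 2 values shown sits. In this assay, among the compounds with values here, compound 2 gives 1730 nM, a measured number rather than a limit; no step between compound 2 and compound 1 is set out here, so only the two values themselves can be read side by side.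

The unmeasured compound 3 `CCCN(CCC)C1=CC(=O)c2c(nc3n2[C@H]2OC[C@@H](O)[C@H]2OC3)C1=O` differs from compound 1 in one place: dipropylamino in place of cyclopropylamino on a double-bonded ring carbon. Within the data shown here, no measured step on this core shows what the change from cyclopropylamino to dipropylamino does in this assay, so no direction can be taken from the data. The account therefore expects a step from compound 1 to compound 3 of a step that the limit leaves unreadable from compound 1 to compound 3, which is no step beyond the scatter. Compound 3 is estimated at 5000 nM, with a range from 1500 nM to 15000 nM, and a substantial chance that the assay again reports only a limit.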

Compound 3, half-maximal inhibitory concentration: > 16000 nM
Compound 3 was reported as a limit; the forecaster's own chance of this, stated with the estimate: 55%; middle value at least 3.2-fold (0.50 log units) away from the limit.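

In this assay compound 3 gives > 16000 nM, which is a limit of the assay and not a number. Compound 1, at > 4000 nM, is also reported as a limit, so no step can be read between compound 1 and compound 3. The compounds shown leave open how far dipropylamino in place of cyclopropylamino shifts activity in this assay.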